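The compounds below may be only part of what the source reports. "The series", "measured", "known", "first", "only" and "open" are said of these compounds alone.

In a physicochemical assay, with a stated time of 6 min (a higher number here means a weaker inhibitor, a lower number a stronger inhibitor), compound 1 `Cc1ccc(NC(=O)Nc2nc(-c3cc4cc(Br)ccc4o3)cs2)cc1` gives > 200000 nM, which is a limit of the assay and not a number. Among the compounds with values here, compound 2 `O=C(Nc1cccc([N+](=O)[O-])c1)Nc1nc(-c2cc3cc(Br)ccc3o2)cs1` gives 159000 nM, the only true number so far, so it has no exact value to be ranked against. Compound 3 `O=C(Nc1nc(-c2cc3cc(Br)ccc3o2)cs1)Nc1ccccc1F` keeps the shared core and has 2-fluorophenyl in place of 3-nitrophenyl on an amide-type nitrogen. Within the data shown here, only one measured step bears on this change, because it alters a group on that same nitrogen: an at least 1.2-fold lower number from compound 1 to compound 2 (0.09 log units; that floor lies within the scatter). From the compounds shown here alone, that step is anchored at one end by a limit rather than a number (the limit of > 200000 nM in this assay, at which 1 of the 2 values shown sits), so its true size remains unknown. It also involves a different pair of groups, which makes it a thin guide. It gives no sign that changing this group moves the number beyond the scatter, and no direction can be drawn from it. On that basis, the expected change is a 1.1-fold lower number from compound 2 to compound 3 (0.03 log units; within the scatter), with no shift beyond the scatter anticipated. For compound 3 the estimated value is 150000 nM, with an expected range from 60000 nM to 200000 nM.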

Compound 3, half-maximal inhibitory concentration: > 200000 nM
Compound 3: no number, only a limit; the forecaster's own chance of this, stated with the estimate: 35%; middle value at least 1.3-fold (0.12 log units) from the limit.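

In this assay compound 3 gives > 200000 nM, which is a limit of the assay and not a number. Within the data shown here, replacing 3-nitrophenyl with 2-fluorophenyl on the amide-type nitrogen gives an at least 1.2-fold higher number from compound 2 to compound 3 (0.09 log units; that floor lies within the scatter), so this second change at the position also shows no step beyond the scatter, and compound 2 remains the only one of the three compounds with a true number. The step between compound 1 and compound 3 cannot be read, and the series now offers little room to measure change at this position, as most of its values stand at the same limit: the limit of > 200000 nM in this assay, at which 2 of the 3 values shown sit.

From the compounds shown here alone, how far compound 1 and compound 3 really lie from compound 2 stays open, and so does whether 3-nitrophenyl truly differs from 4-methylphenyl or 2-fluorophenyl in this assay. Also open, going by these compounds, is what an amine, a carboxylic acid or a longer chain would do on the amide-type nitrogen, and whether any such group could move the number clearly beyond the scatter, toward a stronger inhibitor.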